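A few compounds are considered here, and "the series" means these few. Any claim that something is new, unique, unknown or untested is made for them only; others in the source may bear on it.

In a functional assay on MCF7 cells (Homo sapiens) for inhibition, read by sulforhodamine B assay, with a stated time of 48 h (a higher number here means that more compound is tolerated, a lower number that less compound is tolerated), compound 2, `Nc1cc(N)c2nc(-c3ccccc3)c(NCc3ccc(Cl)c(Cl)c3)nc2c1`, is known only by a limit, < 100000 nM. Compound 1, `Nc1cc(N)c2nc(-c3ccccc3)c(Oc3ccc(Cl)c(Cl)c3)nc2c1`, likewise reaches only a limit in this assay, < 100000 nM. Compound 3, `CCOC(=O)[C@H](CCC(=O)O)NC(=O)c1ccc(Oc2nc3cc(N)cc(N)c3nc2-c2ccccc2)cc1`, also stops at a limit in this assay, < 100000 nM. Every value given so far therefore rests at the same edge of the measurement, (the limit of < 100000 nM in this assay, at which 3 of the 3 values shown sit), and none of them sets a number from which a step could be counted.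

Compound 4, `COc1ccc(CNc2nc3cc(N)cc(N)c3nc2-c2ccccc2)cc1`, differs from compound 2 by 4-methoxyphenyl in place of 3,4-dichlorophenyl on a saturated chain carbon bound to a nitrogen on an aromatic ring. For the measured compounds named here, with no measured step to lean on, the expected step in this assay from compound 2 to compound 4 is a step that the limit leaves unreadable from compound 2 to compound 4, nothing beyond the usual scatter. Compound 4 is accordingly estimated to give 50000 nM in this assay, within a range from 10000 nM to 100000 nM, and most likely again only as a limit.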

Compound 4, concentration lethal to 50% of the cells: 53700 nM
Compound 4: the middle estimate sits 1.1-fold (0.03 log units) below what was measured; the measured number falls inside the stated range.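

For the compounds shown here, no step from compound 2 to compound 4 can be read, because compound 2 is known only by a limit: the limit of < 100000 nM in this assay, at which 3 of the 4 values shown sit. The compounds shown leave open what 4-methoxyphenyl in place of 3,4-dichlorophenyl changes in this assay.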